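Pyrrolidinyl for dimethylamino on a triazolyl benzophenone

This account rests on a few compounds, and the source may have more. Where it says the series, first, only, none or still open, it means among the compounds named here.

The measured compounds:
- compound 1, `NCC(=O)Nc1ccc(Cl)cc1C(=O)c1ccccc1`, 2.5 mg/kg in a functional assay on the whole organism (strain CF-1) for positive allosteric modulation, with Mus musculus as the target; a lower number here means that less compound is needed, a higher number that more compound is needed for the effect
- compound 2, `Cc1nnc(CN)n1-c1ccc(Cl)cc1C(O)c1ccccc1`, 3.1 mg/kg in this assay
- compound 3, `Cc1nnc(CN(C)C)n1-c1ccc(Cl)cc1C(=O)c1ccccc1`, 1.1 mg/kg in this assay

Among these three numbers compound 3 has the lowest. Its gap to compound 1, the nearest of the other two, lies beyond the usual scatter, as does its larger gap to compound 2, so compound 3 is the most potent of the three on this read-out.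

Compound 4, `Cc1nnc(CN2CCCC2)n1-c1ccc(Cl)cc1C(=O)c1ccccc1`, is not yet measured. It differs from compound 3 in one place: pyrrolidin-1-yl in place of dimethylamino on a saturated chain carbon bound to an aromatic carbon. Going by the values given here, no pair of measured compounds differing only in this way is available, so the direction of the step cannot be read from the data. A change of this kind, an open chain amine to a ring amine of similar size, is expected to move the dose for half-maximal effect little, and no step beyond the scatter is expected. On that basis the estimate for the step from compound 3 to compound 4 in this assay is a 1.2-fold higher number from compound 3 to compound 4 (0.07 log units; within the scatter). Compound 4 is therefore expected to give about 1.3 mg/kg in this assay, within a range of 0.5 mg/kg to 3.5 mg/kg.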

Compound 4, dose for half-maximal effect: 1.8 mg/kg
Compound 4: the middle estimate sits 1.4-fold (0.14 log units) below what was measured, within the range that was stated.
By their numbers in this assay, from the lowest: compounds 3, 4, 1 and 2 (each within the scatter of the next, the first and the last beyond it).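

In this assay, going by these compounds alone, putting pyrrolidin-1-yl in place of dimethylamino on a saturated chain carbon bound to an aromatic carbon gives a 1.6-fold higher number from compound 3 to compound 4 (0.21 log units; within the scatter), the first step at this place that can be read. This step lies within the scatter, so this place tolerates the larger group with its five-membered non-aromatic ring, and the two compounds cannot be told apart on this read-out. Nothing at hand explains the result or ties it to any property of either group.

The compounds shown leave open whether piperidine, morpholine or a longer chain at this place would also stay within the scatter. They also leave open whether the same exchange would give a similar step on a core other than that of compound 3.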